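Swapping a methoxyphenyl for thiophene: what to expect

This account rests on a few compounds, and the source may have more. Where it says the series, first, only, none or still open, it means among the compounds named here.

Compound 1 `COc1ccc(-c2nc3cccc(-c4cc(OC)c(OC)c(OC)c4)c3o2)cc1`: 3500 nM
Compound 2 `COc1cccc(-c2nc3cccc(-c4cc(OC)c(OC)c(OC)c4)c3o2)c1`: > 25000 nM
Compound 3 `COc1ccc(-c2nc3cccc(-c4cc(OC)c(OC)c(OC)c4)c3o2)cc1OC`: > 25000 nM

In a functional assay on NCI-H460 cells (Homo sapiens) for antiproliferative activity, read by MTT assay, with a stated time of 48 h (on this read-out lower numbers stand for stronger inhibition and higher numbers for weaker inhibition), compound 1 gives 3500 nM. For compound 2 this assay reports only a limit, > 25000 nM. For compound 3 it likewise reports only a limit, > 25000 nM. Compound 2 thus stands at the limit of > 25000 nM in this assay, at which 2 of the 3 values shown sit. Compound 1 is the only one of the three with a read number. Compound 4 `COc1cc(-c2cccc3nc(-c4cccs4)oc23)cc(OC)c1OC` differs from compound 2 in one place: thiophen-2-yl in place of 3-methoxyphenyl on an aromatic carbon. The measured steps that bear on a change of the group at this place are an at least 7.1-fold higher number from compound 1 to compound 2 (0.85 log units; beyond the scatter) and an at least 7.1-fold higher number from compound 1 to compound 3 (0.85 log units; beyond the scatter), both beyond the scatter; a step that the two limits leave unreadable from compound 2 to compound 3 stays unreadable as both its values are limits. Going by the values given here, no measured step involves thiophen-2-yl, so the direction is open. Compound 4 is estimated at 10000 nM (range 2000 nM to 40000 nM), which means an expected at least 2.5-fold lower number from compound 2 to compound 4 (0.39 log units; beyond the scatter).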

Compound 4, half-maximal inhibitory concentration: 1600 nM
For compound 4 the middle estimate is 6.3-fold (0.80 log units) above the measured one; the measured number lies below the stated range.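

Thiophen-2-yl at this place clearly outperforms the two phenyl groups that sit at the limit: the step of an at least 15-fold lower number from compound 2 to compound 4 (1.19 log units; beyond the scatter) and the step of an at least 15-fold lower number from compound 3 to compound 4 (1.19 log units; beyond the scatter) are both large. It also improves on the one methoxyphenyl with a read number, with a 2.2-fold lower number from compound 1 to compound 4 (0.34 log units; beyond the scatter) being modest but beyond the scatter, so a five-membered ring with sulfur works here in place of a six-membered carbon ring. Both large steps start from a limit, so they give only a minimum size: the limit of > 25000 nM in this assay, at which 2 of the 4 values shown sit.

From the compounds shown here alone, what furan-2-yl or a plain phenyl would give at this place stays open. The compounds shown therefore cannot say whether the sulfur atom or the smaller ring matters more.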